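This account rests on a few compounds, and the source may have more. Where it says the series, first, only, none or still open, it means among the compounds named here.

Measured compounds:
Compound 1, `COc1ccc(C2CC(c3ccccc3)=NN2C2=NC(=O)/C(=C3\C(=O)Nc4ccc(Br)cc43)S2)cc1`, in a functional assay on cells (Cancer cell lines, Homo sapiens) for cytotoxicity, read by sulforhodamine B assay, with a stated time of 48 h (on this read-out higher numbers stand for weaker inhibition of growth and lower numbers for stronger inhibition of growth), gives 230 nM.
Compound 2, `COc1ccc(C2=NN(C3=NC(=O)/C(=C4\C(=O)Nc5ccc(Br)cc54)S3)C(c3ccc(OC)cc3)C2)cc1`, in this assay gives 240 nM.
Compound 3, `O=C1N=C(N2N=C(c3ccccc3)CC2c2ccc(Cl)cc2)S/C1=C1/C(=O)Nc2ccccc21`, in this assay gives 230 nM.

Compound 4, `COc1ccc(C2=NN(C3=NC(=O)/C(=C4\C(=O)Nc5ccccc54)S3)C(c3ccc(Cl)cc3)C2)cc1`, has not yet been measured.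

Compound 2 differs from compound 1 by methoxy in place of hydrogen on an aromatic carbon. This change gave a 1.0-fold higher number from compound 1 to compound 2 (0.02 log units; within the scatter). Compound 3 carries a different core from compound 1; the difference between the two cores is not broken down here. Compound 3 and compound 1 give numbers that are level at the digits read, and compound 2 lies within the scatter of both. Compound 4 differs from compound 3 by methoxy in place of hydrogen on an aromatic carbon, the same change as that made from compound 1 to compound 2, at a place described in the same words. Going by the values given here, the expectation for the step from compound 3 to compound 4 in this assay is no change at the digits printed from compound 3 to compound 4 (within the scatter), a step within the scatter, resting on a 1.0-fold higher number from compound 1 to compound 2 (0.02 log units; within the scatter) as the only measured instance of this change. Among the compounds with values here, compound 4 is accordingly estimated at 230 nM, with a range from 130 nM to 420 nM to allow for the scatter of the assay and the single precedent.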

Compound 4, concentration for 50% growth inhibition: 100000 nM
The estimate for compound 4 lay 430-fold (2.64 log units) below the measured number; measured number outside the range, above it.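

In this assay, phenyl to 4-methoxyphenyl gave a 430-fold higher number from compound 3 to compound 4 (2.64 log units; beyond the scatter), and the result on one core did not predict the result on the other: the same change on two cores in this assay, a 1.0-fold higher number (0.02 log units; within the scatter) from compound 1 to compound 2 and a 430-fold higher number (2.64 log units; beyond the scatter) from compound 3 to compound 4, 420-fold (2.62 log units) apart, beyond the scatter of two such steps

This shows that, in this series, a flat step on the core of compound 1 gives no licence to assume a flat step elsewhere, and that the effect of this change depends on the core carrying it. It does not show which feature of the core decides the outcome, as the two cores differ in more than one place, nor does it give a general rule, as each core rests on a single pair.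

Still open, as far as these compounds go, is whether the bromo group present in compound 1 and compound 2, set on the core of compound 4, would alter its number. Also open, from the compounds shown here alone, is whether ethoxy, hydroxyl or an amine at the same place on the core of compound 3 would give a step of similar size.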